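Trading a Pentyl Chain for Methoxycarbonyl

A few compounds are considered here, and "the series" means these few. Any claim that something is new, unique, unknown or untested is made for them only; others in the source may bear on it.

Among the compounds with values here, in a physicochemical assay for lipophilicity, measured as octanol-water partition (on this read-out higher numbers stand for higher lipophilicity and lower numbers for lower lipophilicity), compound 1 `CCCCCc1cn(CC=C(C)C)nn1` gives 3.46, the lower of the two numbers measured so far, and compound 2 `CCCCCc1cn(C/C=C(\C)CCC=C(C)C)nn1` gives 5.45. Compound 3 `COC(=O)c1cn(CC=C(C)C)nn1` keeps the core of compound 1 but has methoxycarbonyl in place of pentyl on an aromatic carbon.

Within the data shown here, only one measured step bears on this change, and only loosely. Adding a 3-methylbut-2-en-1-yl group in place of hydrogen on a saturated chain carbon goes with a number 1.99 log units higher from compound 1 to compound 2 (beyond the scatter), a large rise. That step is a gain of carbon chain and involves a different group, whereas compound 3 loses a carbon chain and takes on a group with oxygen. A single step cannot settle the size of this one, but a fall in this assay of similar size, well beyond the scatter, is a reasonable expectation. The expected change is a number 2.06 log units lower from compound 1 to compound 3 (beyond the scatter). For compound 3 the estimated value is 1.4, with an expected range from 0.8 to 2.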

Compound 3, partition coefficient: 1.3
Beside the measured number, compound 3's estimate is 0.10 log units above it; low and high end bracket the measured number.
By their numbers in this assay, from the lowest: compound 3; then compound 1; then compound 2.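

On the aromatic carbon of the shared core, the read-out of this assay depends strongly on the group held there: methoxycarbonyl in place of pentyl gives a number 2.16 log units lower from compound 1 to compound 3 (beyond the scatter). Within the data shown here, the earlier step, a number 1.99 log units higher from compound 1 to compound 2 (beyond the scatter), concerned only the chain carrying the 3-methylbut-2-en-1-yl group, so this is the first measured change at the aromatic carbon, and it shows that a large step is possible in the downward direction as well. The swap removes a pentyl chain made only of carbon and brings in a group with 2 oxygen and 2 hydrogen-bond acceptors, but no measurement shown here explains the size of the step.

The compounds shown do not separate the loss of the pentyl chain from the arrival of the oxygen atoms, so how much of the step belongs to each remains open. A propyl chain, a carboxylic acid or an amine on the same aromatic carbon could help divide it, and the same swap on the core of compound 2 would test whether the step keeps its size there.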